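A few compounds are considered here, and "the series" means these few. Any claim that something is new, unique, unknown or untested is made for them only; others in the source may bear on it.

Compound 1, with the structure `CCC(=O)c1c(C)nn(CCCN2CCN(c3ccc(C)cc3)CC2)c(=O)c1N`, was tested in a functional assay on the whole organism (Abdomen, strain Swiss) for inhibition, with Mus musculus as the target, with stated times of 30 min, 10 min and 5 min, at a dose of 20 mg/kg by the oral route (a lower number here means a weaker effect, a higher number a stronger effect of the compound at the dose given), and gave 40%. Compound 2, with the structure `CC/C=C/c1c(C)nn(CCCN2CCN(c3ccc(C)cc3)CC2)c(=O)c1N`, differs from it by but-1-en-1-yl in place of propanoyl on an aromatic carbon; in this assay compound 2 gives 35%. The step between them is a number 5 percentage points lower from compound 1 to compound 2 (within the scatter), so the two measured compounds stand level with each other within the scatter, and compound 2 stands alongside compound 1 rather than apart from it.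

Compound 3, with the structure `CCC/C=C/c1c(C)nn(CCCN2CCN(c3ccc(C)cc3)CC2)c(=O)c1N`, has not yet been measured. Its difference from compound 2 is methyl in place of hydrogen on a saturated chain carbon, two bonds along the chain from a double-bonded chain carbon. Among the compounds with values here, no measured step covers this kind of change: the only step known, that from compound 1 to compound 2, exchanges one whole group for another at the aromatic carbon and is itself within the scatter. A small extension of a chain that already sits there gives no reason to expect a move beyond the scatter in this assay. The step expected here is no change at the digits printed from compound 2 to compound 3 (within the scatter). Compound 3 is therefore estimated to give 35%, with a range from 20% to 50%.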

Compound 3, a percentage reported as inhibition, in the whole organism at one dose (the size of the read-out at that dose, not a potency): 16%
Compound 3: the middle estimate sits 19 percentage points above what was measured, outside the stated range (below it).
By their numbers in this assay, from the lowest: compound 3; then compounds 2 and 1 (each within the scatter of the next).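

In this assay, this position on the aromatic carbon proves sensitive to a very small change: adding one methyl on a saturated chain carbon, two bonds along the chain from a double-bonded chain carbon, turns but-1-en-1-yl into pent-1-en-1-yl and gives a number 19 percentage points lower from compound 2 to compound 3 (beyond the scatter). The earlier exchange of propanoyl for but-1-en-1-yl stayed within the scatter, so that pair alone gave no sign that the group at this carbon could matter, whereas pent-1-en-1-yl in place of propanoyl gives a number 24 percentage points lower from compound 1 to compound 3 (beyond the scatter). Nothing available bears on the reason for this drop, so the result stands as an observation without an explanation.

On these data alone, with only these three compounds, it remains open whether a longer chain such as hex-1-en-1-yl would lower the number further, or whether the drop belongs to pent-1-en-1-yl alone. As far as these compounds go, it is also open how a pentanoyl group, which has the carbonyl of compound 1 and a longer chain, or a saturated pentyl chain would behave at the same aromatic carbon, and each read-out here reflects a single dose rather than a potency.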